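The source may report more compounds than this note shows. Statements on the series, on what has been measured and on what is new or still open speak of the compounds shown alone.

Measured so far in a functional assay on HL-60 cells (Homo sapiens), read by calcium flux; on this read-out lower numbers stand for an effect already at smaller amounts and higher numbers for an effect only at larger amounts of compound:
compound 1 `Cc1cc(Cc2cccc(Br)c2)c(=O)n(CC(=O)Nc2ccc(Br)cc2)n1`: > 50000 nM
compound 2 `Cc1cc(Cc2ccc(C(N)=O)cc2)c(=O)n(CC(=O)Nc2ccc(Br)cc2)n1`: > 50000 nM
Not yet measured: compound 3 `COc1ccc(-c2cc(C)nn(CC(=O)Nc3ccc(Br)cc3)c2=O)cc1`.

Compound 1 stands at a limit of this assay: the value > 50000 nM is not a number but the edge of what was measured. Compound 2 likewise gives > 50000 nM in this assay, which is also a limit. The step that the two limits leave unreadable from compound 1 to compound 2 is therefore unreadable because the limit of > 50000 nM in this assay, at which 2 of the 2 values shown sit, covers both of its ends; it says nothing about direction or size.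

Compound 3 differs from compound 1 by 4-methoxyphenyl in place of 3-bromobenzyl on an aromatic carbon. Going by the values given here, no measured step bears on this change, and the single step gives no readable size. With both measured compounds at the limit, compound 3 is expected in the same region, at 60000 nM, with a range from 15000 nM to 200000 nM. The expected step that the limit leaves unreadable from compound 1 to compound 3 is accordingly small, and a limit rather than a number is the likelier outcome.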

Compound 3, half-maximal effective concentration: > 50000 nM
Compound 3 was reported as a limit (the forecaster's own chance of this, stated with the estimate: 75%); the middle value does not contradict the limit.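

In this assay compound 3 gives > 50000 nM as a limit, not a number. Going by these compounds alone, no step from compound 1 to compound 3 can be read, since the result adds only another limit: the limit of > 50000 nM in this assay, at which 3 of the 3 values shown sit. The compounds shown leave open whether any change on the shared core gives a measurable value.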